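Fluoro in place of ethyl on compound 2

This account rests on a few compounds, and the source may have more. Where it says the series, first, only, none or still open, it means among the compounds named here.

Of the compounds shown here, three sharing one core have been measured in a physicochemical assay for lipophilicity, at pH 7.4; on this read-out lower numbers stand for lower lipophilicity and higher numbers for higher lipophilicity. Compound 1 `CCc1ccc(N(C2CCC2)S(=O)(=O)c2ccc3c(c2)C(O)CC(C2CCOCC2)O3)cc1` gives 3.69, compound 3 `CCc1ccc(N(CC(C)C)S(=O)(=O)c2ccc3c(c2)C(O)CC(C2CCNCC2)O3)cc1` gives 1.04, and compound 2 `CCc1ccc(N(CC(C)C)S(=O)(=O)c2ccc3c(c2)C(O)CC(C2CCOCC2)O3)cc1` stands highest of the three at 4.12. Compound 4 `CC(C)CN(c1ccc(F)cc1)S(=O)(=O)c1ccc2c(c1)C(O)CC(C1CCOCC1)O2` differs from compound 2 in one place, with fluoro in place of ethyl on an aromatic carbon, para to a large group (fluoro in place of ethyl on an aromatic carbon).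

Two measured steps offer a scale. Isobutyl in place of cyclobutyl on a sulfonamide nitrogen gave a number 0.43 log units higher from compound 1 to compound 2 (beyond the scatter), a modest step. Piperidin-4-yl in place of oxan-4-yl on a saturated ring carbon gave a number 3.08 log units lower from compound 2 to compound 3 (beyond the scatter), a large one. Among the compounds with values here, neither step concerns the place that changes here, so the data hold no direct precedent, and they serve only as a guide to size. A downward step somewhat larger than the modest one and far smaller than the large one is expected, estimated at a number 0.72 log units lower from compound 2 to compound 4 (beyond the scatter) in this assay. For compound 4 the expected value is 3.4, within an estimated range of 3 to 3.8.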

Compound 4, distribution coefficient: 3.39
The estimate for compound 4 lay 0.01 log units above the measured number; the measured number falls inside the stated range.
By their numbers in this assay, from the lowest: compound 3; then compounds 4 and 1 (each within the scatter of the next); then compound 2.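

In this assay, within the data shown here, the change from 4-ethylphenyl to 4-fluorophenyl gave a number 0.73 log units lower from compound 2 to compound 4 (beyond the scatter), the first reading at this place, since ethyl sits on the aromatic carbon, para to a large group, in compounds 1, 2 and 3 alike. The read-out therefore responds to this position, though the step is smaller than the one seen on the saturated ring carbon, a number 3.08 log units lower from compound 2 to compound 3 (beyond the scatter), where piperidin-4-yl replaced oxan-4-yl. The data give no measured basis for explaining the step.

With ethyl and fluoro alone at this place, the compounds shown do not separate the loss of the two-carbon chain from the arrival of fluorine, which hydrogen, methyl or chloro there could help to resolve. Going by these compounds, whether the step would hold with cyclobutyl on the sulfonamide nitrogen, or with piperidin-4-yl on the saturated ring carbon, also remains open.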